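Amide nitrogen change from compound 3 to compound 4

The source may hold more compounds than are shown below. What is called first, only, known or untested is meant among the compounds shown, and "the series" means these compounds.

Compound 1 `C=CC1=C(C(=O)NC2CCCCC2)C(c2ccc(OC)cc2)OC1`: in a functional assay on QGY7701 cells (Homo sapiens) for cytotoxicity, read by MTT assay, with a stated time of 24 h (on this read-out lower numbers stand for stronger inhibition and higher numbers for weaker inhibition), compound 1 gives > 100000 nM, a limit of the assay.
Compound 2 `C=CC1=C(C(=O)Nc2ccc(C)cc2)C(c2ccc(F)cc2)OC1`: in this assay compound 2 gives 59200 nM.
Compound 3 `C=CC1=C(C(=O)NCc2ccc(C)cc2)C(c2ccc(OC)cc2)OC1`: in this assay compound 3 gives 43100 nM.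

Compound 3 holds the lowest of the two numbers; compound 2 is the nearest and lies within the scatter of it. Within the data shown here, the one measured change at the amide nitrogen is an at least 2.3-fold lower number from compound 1 to compound 3 (0.36 log units; beyond the scatter), and compound 1 sits at the limit of > 100000 nM in this assay, at which 1 of the 3 values shown sits, so the true size of that step is not known. Compound 4 `C=CC1=C(C(=O)Nc2ccc(C)cc2)C(c2ccc(OC)cc2)OC1` differs from compound 3 by 4-methylphenyl in place of 4-methylbenzyl on an amide-type nitrogen. Compound 2 carries the same 4-methylphenyl on its amide nitrogen and shows a number close to that of compound 3. Compound 4 is therefore expected to stay within the scatter of compound 3, with a 1.3-fold higher number from compound 3 to compound 4 (0.11 log units; within the scatter). The estimate for compound 4 is 55000 nM, between 25000 nM and 120000 nM.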

Compound 4, half-maximal inhibitory concentration: > 100000 nM
Compound 4: a limit, no number (the forecaster's own chance of this, stated with the estimate: 20%); middle value at least 1.8-fold (0.25 log units) from the limit.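

On the amide-type nitrogen, 4-methylphenyl does not stand in for 4-methylbenzyl when methoxy sits on the aromatic carbon, the first change printing as an at least 2.3-fold higher number from compound 3 to compound 4 (0.36 log units; beyond the scatter). Methoxy in place of fluoro on an aromatic carbon prints as an at least 1.6-fold higher number from compound 2 to compound 4 (0.22 log units; that floor lies within the scatter), so that change has no size readable beyond the scatter. Compound 4 gives a limit, not a number, so both steps are floors and the step involving compound 1 cannot be read: the limit of > 100000 nM in this assay, at which 2 of the 4 values shown sit.

As far as these compounds go, whether a 2-phenylethyl group on the amide-type nitrogen would hold the number of compound 3 stays open. So does the effect of fluoro with 4-methylbenzyl there.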